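Aryl ether carbamates: dichlorophenyl in place of methoxyphenyl

The source may hold more compounds than are shown below. What is called first, only, known or untested is meant among the compounds shown, and "the series" means these compounds.

The series shares the core of compound 1 `CCC(COc1ccccc1)OC(=O)NCc1ccccc1`; compound 2 `CCC(COc1cccc(F)c1)OC(=O)NCc1ccccc1` and compound 3 `CCC(COc1cccc(OC)c1)OC(=O)NCc1ccccc1` differ from it only by the substituent on the aromatic ring of the ether. In an assay for inhibition of zeta-carotene desaturase, chloroplastic/chromoplastic (Capsicum annuum), using a Dixon plot, with a stated time of 8 h (a lower number here means a stronger inhibitor, a higher number a weaker inhibitor), compound 1 gives > 100000 nM, which is a limit of the assay. In this assay compound 2 gives > 100000 nM, again a limit. Compound 3 gives > 100000 nM in this assay, also a limit. For the measured compounds named here, because the limit of > 100000 nM in this assay, at which 3 of the 3 values shown sit, none of the measured steps can be read: a step that the two limits leave unreadable from compound 1 to compound 2, a step that the two limits leave unreadable from compound 1 to compound 3 and a step that the two limits leave unreadable from compound 2 to compound 3. Compound 3 therefore stands at the limit, with nothing to separate it from compound 1 or compound 2.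

Compound 4 `CCC(COc1cccc(Cl)c1Cl)OC(=O)NCc1ccccc1` carries 2,3-dichlorophenyl in place of 3-methoxyphenyl on an oxygen on a saturated carbon. Going by the values given here, the measured steps all concern substituents on the same aromatic ring, and all are unreadable, so they give neither a direction nor a size for this exchange; no measured compound shows a number in this assay. The step that the limit leaves unreadable from compound 3 to compound 4 is therefore expected to be unreadable as well. The estimate for compound 4 in this assay is 150000 nM, within 30000 nM to 1000000 nM, and it is expected that this assay most likely reports only a limit once more.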

Compound 4, half-maximal inhibitory concentration: > 100000 nM
Compound 4: only a limit was reported (the forecaster's own chance of this, stated with the estimate: 80%); the middle value is on the limit's open side.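

The steps from compound 1, compound 2 and compound 3 to compound 4 cannot be read in this assay, and all share one cause: the limit of > 100000 nM in this assay, at which 4 of the 4 values shown sit. The compounds shown leave open whether any substituent on the aromatic ring of the ether gives a measurable inhibition in this assay, and how far these compounds differ from one another.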